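From methoxy to hydroxy on compound 2

The source may hold more compounds than are shown below. What is called first, only, known or untested is meant among the compounds shown, and "the series" means these compounds.

In a functional assay on SW-620 cells (Homo sapiens) for cytotoxicity, read by MTT assay, with a stated time of 72 h (a lower number here means a stronger inhibitor, a higher number a weaker inhibitor), compound 1 (`COc1cccc(/C=C2\CCC/C(=C\c3ccccc3Cl)C2=O)c1OC`) gives 10300 nM, and compound 2 (`COc1cccc(/C=C2\CCC/C(=C\c3cccc(OC)c3OC)C2=O)c1`) gives 7000 nM. These two values lie within the scatter of each other, so compound 2 stands level with compound 1. Compound 3 (`COc1cccc(/C=C2\CCC/C(=C\c3cccc(O)c3)C2=O)c1OC`) has hydrogen in place of methyl on an oxygen on an aromatic ring, turning 3-methoxyphenyl into 3-hydroxyphenyl: hydrogen in place of methyl on an oxygen on an aromatic ring. Among the measured compounds shown here, the only measured step, a 1.5-fold lower number from compound 1 to compound 2 (0.17 log units; within the scatter), replaces a different group and stays within the scatter, so it offers only weak guidance, and no shift beyond the scatter is expected. The estimated change is a 1.2-fold lower number from compound 2 to compound 3 (0.07 log units; within the scatter). For compound 3 the expected value is 6000 nM, with an estimated range of 2500 nM to 14000 nM.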

Compound 3, half-maximal inhibitory concentration: 6400 nM
Compound 3: middle estimate off by 1.1-fold (0.03 log units), on the low side, within the range that was stated.
By their numbers in this assay, from the lowest: compounds 3, 2 and 1 (each within the scatter of the next).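

In this assay, removing the methyl from this oxygen on an aromatic ring gives a 1.1-fold lower number from compound 2 to compound 3 (0.04 log units; within the scatter), so a free hydroxy stands level with methoxy here. Set against 2-chlorophenyl, 3-hydroxyphenyl gives a 1.6-fold lower number from compound 1 to compound 3 (0.21 log units; within the scatter), so this group also stands level with that one, and all three groups seen at this place fall within the scatter. No supporting evidence bears on this result.

The compounds shown leave open whether an amine or a carboxylic acid in place of the hydroxy would give a step beyond the scatter. They also leave open whether a longer chain on this oxygen would do so.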